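Removing a methyl from an inactive fused core

The source may hold more compounds than are shown below. What is called first, only, known or untested is meant among the compounds shown, and "the series" means these compounds.

Compound 1, `Cc1coc2c3c(ccc2c1=O)OC[C@H]1[C@@H]3C2=C(CCCC2=O)OC1(C)C`: > 100000 nM
Compound 2, `Cc1oc2c3c(ccc2c(=O)c1C)OC[C@H]1[C@@H]3C2=C(CC(C)(C)CC2=O)OC1(C)C`: > 100000 nM

In a functional assay on A549 cells (Homo sapiens) for antiproliferative activity, read by MTT assay, with a stated time of 48 h (on this read-out higher numbers stand for weaker inhibition and lower numbers for stronger inhibition), compound 1 reaches only the limit of the assay, > 100000 nM. In this assay compound 2 likewise reaches only the limit, > 100000 nM. Compound 2 therefore stands at the ceiling of what the assay reports, as stated by the limit of > 100000 nM in this assay, at which 2 of the 2 values shown sit. Compound 3, `Cc1coc2c3c(ccc2c1=O)OC[C@H]1[C@@H]3C2=C(CC(C)(C)CC2=O)OC1(C)C`, differs from compound 2 by hydrogen in place of methyl on an aromatic carbon. Among the measured compounds shown here, no step between measured compounds is available, so no measured effect of this change is known. Compound 3 is expected to remain at the limit, estimated at 100000 nM within 50000 nM to 200000 nM. The step of a number no higher from compound 2 to compound 3 (the limit leaves the size open) is accordingly expected to be none beyond the scatter.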

Compound 3, half-maximal inhibitory concentration: > 100000 nM
Compound 3 was reported as a limit (the forecaster's own chance of this, stated with the estimate: 85%); the middle value sits exactly at the limit.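

Among the compounds shown here, compound 2 and compound 3 both give only a limit, so no step between them can be read: the limit of > 100000 nM in this assay, at which 3 of the 3 values shown sit. On these data alone, whether hydrogen in place of methyl matters on a core with a measurable value in this assay stays open.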